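A Fluoro-for-Chloro Exchange on a Shared Core

This account rests on a few compounds, and the source may have more. Where it says the series, first, only, none or still open, it means among the compounds named here.

Compound 1 `CC1=C(C(=O)Nc2ccc([N+](=O)[O-])cc2)C(c2ccc(Br)cc2)N=C(SCc2cccc(Cl)c2)N1`: 5.1%
Compound 2 `CC1=C(C(=O)Nc2ccc([N+](=O)[O-])cc2)C(c2ccc(Br)cc2)N=C(SCc2ccc(Cl)cc2)N1`: 34.4%

In a functional assay on the whole organism (artery, strain albino) with Rattus norvegicus as the target, with a stated time of 600 min, at a dose of 10 mg/kg by the oral route (on this read-out lower numbers stand for less inhibition and higher numbers for more inhibition at the one dose given (going by the name of the read-out)), compound 2 gives 34.4%, the higher of the two numbers measured, while compound 1 gives 5.1%. For the measured compounds named here, the one measured step, a number 29.3 percentage points higher from compound 1 to compound 2 (beyond the scatter), concerns 4-chlorophenyl in place of 3-chlorophenyl and does not bear on the change now at hand. Compound 3 `CC1=C(C(=O)Nc2ccc([N+](=O)[O-])cc2)C(c2ccc(Br)cc2)N=C(SCc2ccc(F)cc2)N1` differs from compound 2 by fluoro in place of chloro on an aromatic carbon. Going by the values given here, no measured step speaks to this exchange, so no step beyond the scatter is expected. Compound 3 is estimated at 26%, between 6% and 48%. The expected step is a number 8.4 percentage points lower from compound 2 to compound 3 (within the scatter).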

Compound 3, a percentage reported as inhibition, in the whole organism at one dose (the size of the read-out at that dose, not a potency): 32.3%
Compound 3: the middle estimate sits 6.3 percentage points below what was measured; measured number inside the range.
By their numbers in this assay, from the lowest: compound 1; then compounds 3 and 2 (each within the scatter of the next).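

Para to a large group, a number 2.1 percentage points lower from compound 2 to compound 3 (within the scatter) in this assay with fluoro in place of chloro, so at this position the two halogens cannot be told apart on this read-out. The difference from the 3-chlorophenyl compound also persists with fluoro, as a number 27.2 percentage points higher from compound 1 to compound 3 (beyond the scatter) shows once more beyond the scatter. No measurement here offers a reason for either result.

As far as these compounds go, whether this position accepts anything other than a halogen remains open, for instance a methoxy group, a trifluoromethyl group or plain hydrogen. Also open, from the compounds shown here alone, is whether 3-fluorophenyl would stay as low as 3-chlorophenyl.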